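The source may hold more compounds than are shown below. What is called first, only, known or untested is meant among the compounds shown, and "the series" means these compounds.

Measured so far:
compound 1 `O=C(NCc1ccccc1)c1c(O)c2cccnc2n(-c2ccccc2)c1=O`: 1.6%
compound 2 `Cc1ccc(NC(=O)c2c(O)c3cccnc3n(-c3ccccc3)c2=O)cc1`: -3.5%
compound 3 `O=C(Nc1ccc([N+](=O)[O-])cc1)c1c(O)c2cccnc2n(-c2ccccc2)c1=O`: -7.6%

All three numbers come from a functional assay on the whole organism for inhibition, with Rattus norvegicus as the target, read by paw edema, at a dose of 100 mg/kg by the oral route; on this read-out lower numbers stand for less inhibition and higher numbers for more inhibition at the one dose given (going by the name of the read-out). Compound 3 gives the lowest of the three numbers, yet both steps leading to it, a number 9.2 percentage points lower from compound 1 to compound 3 (within the scatter) and a number 4.1 percentage points lower from compound 2 to compound 3 (within the scatter), stay within the scatter, so the three compounds cannot really be told apart. Compound 4 `O=C(Nc1cccc(Cl)c1)c1c(O)c2cccnc2n(-c2ccccc2)c1=O` is next to be measured. Its change from compound 3 is 3-chlorophenyl in place of 4-nitrophenyl on an amide-type nitrogen. Going by the values given here, the closest measured step, another swap of the group on the amide-type nitrogen, was a number 5.1 percentage points lower from compound 1 to compound 2 (within the scatter), again within the scatter; no step moved the read-out beyond it. The expected step is therefore a number 5.6 percentage points higher from compound 3 to compound 4 (within the scatter), none beyond the scatter. Compound 4 is estimated at -2%, between -12% and 9%.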

Compound 4, a percentage reported as inhibition, in the whole organism at one dose (the size of the read-out at that dose, not a potency): 7.6%
The estimate for compound 4 lay 9.6 percentage points below the measured number, within the range that was stated.
By their numbers in this assay, from the lowest: compounds 3, 2, 1 and 4 (each within the scatter of the next, the first and the last beyond it).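

In this assay, going by these compounds alone, the group on the amide-type nitrogen now makes a readable difference for the first time, with a number 15.2 percentage points higher from compound 3 to compound 4 (beyond the scatter) and a number 11.1 percentage points higher from compound 2 to compound 4 (beyond the scatter) when 3-chlorophenyl enters. The same group does not separate from benzyl, with a number 6 percentage points higher from compound 1 to compound 4 (within the scatter) for that swap. Nothing measured here explains these steps. Going by these compounds, whether an amine or a carboxylic acid on the phenyl ring, or a longer chain on the amide-type nitrogen, would lift the read-out well clear of these small numbers stays open. So does whether these differences would hold at any other dose.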